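This account rests on a few compounds, and the source may have more. Where it says the series, first, only, none or still open, it means among the compounds named here.

In an assay on the whole organism (plasma, strain Sprague-Dawley) for inhibition of Dipeptidyl peptidase 4 (Rattus norvegicus), with a stated time of 6 h, at a dose of 1 mg/kg by the oral route (on this read-out higher numbers stand for more inhibition at the one dose given (going by the name of the read-out) and lower numbers for less inhibition), compound 2 `N#C[C@@H]1CCCN1C(=O)[C@@H]1C[C@H](CO)CN1` gives 64%, the lowest of the three numbers at hand. Compound 1 `N#C[C@@H]1CCCN1C(=O)[C@@H]1C[C@H](C(=O)N2CCOCC2)CN1` gives 73%, a number within the scatter of that for compound 2, so no order between the two can be read. Compound 3 `C[C@@H]1N[C@H](C(=O)N2CCC[C@H]2C#N)C[C@@H]1C(=O)N1CCC1` gives 94%, which stands beyond the scatter above compound 2. The unmeasured compound 4 `N#C[C@@H]1CCCN1C(=O)[C@@H]1C[C@H](CCO)CN1` differs from compound 2 in a single place: hydroxymethyl in place of hydroxy on a saturated chain carbon bound to a saturated ring carbon. Going by the values given here, no measured pair shows a step of this kind, so the numbers give no direction for it, and a change this small is expected to shift the read-out by no more than the scatter. Compound 4 is therefore estimated at 65%, with a range from 45% to 82%. The expected step is a number 1 percentage points higher from compound 2 to compound 4 (within the scatter), within the scatter.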

Compound 4, a percentage reported as inhibition, in the whole organism at one dose (the size of the read-out at that dose, not a potency): 64%
Estimate against measurement, compound 4: 1 percentage points above, within the range that was stated.
By their numbers in this assay, from the lowest: compounds 2, 4 and 1 (each within the scatter of the next); then compound 3.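

In this assay, going by these compounds alone, the first step that can be read at this place is no change at the digits printed from compound 2 to compound 4 (within the scatter) on going from hydroxymethyl to 2-hydroxyethyl. At the one dose given, the read-out therefore does not register this one-carbon extension of the chain on the saturated ring carbon. Nothing at hand bears on the reason for this result. From the compounds shown here alone, whether an amine, a carboxylic acid or a 3-hydroxypropyl chain at this place would leave the read-out unmoved stays open. Also open, going by these compounds, is whether the step would look the same at another dose or time.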